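A second methoxy on compound 2

A few compounds are considered here, and "the series" means these few. Any claim that something is new, unique, unknown or untested is made for them only; others in the source may bear on it.

In a functional assay on HT-29 cells (Homo sapiens) for antiproliferative activity, read by sulforhodamine B assay, with a stated time of 48 h (a higher number here means a weaker inhibitor, a lower number a stronger inhibitor), compound 2 `CCN1CCN(c2ccc(S(=O)(=O)Oc3cccc(OC)c3)cc2)C1=O` at 22000 nM holds the higher of the two numeric values, and compound 1 `COc1cc(OC)cc(OS(=O)(=O)c2ccc(N3CCN(C)C3=O)cc2)c1` at 190 nM holds the lower one. Compound 3 `CCN1CCN(c2ccc(S(=O)(=O)Oc3cccc(F)c3)cc2)C1=O` gives only a limit of the assay at > 100000 nM in this series. Fluoro in place of methoxy on an aromatic carbon gives an at least 4.5-fold higher number from compound 2 to compound 3 (0.65 log units; beyond the scatter) and is the only measured step. Compound 4 `CCN1CCN(c2ccc(S(=O)(=O)Oc3cc(OC)cc(OC)c3)cc2)C1=O` takes methoxy in place of hydrogen on an aromatic carbon meta to a methoxy group. Within the data shown here, no measured step adds such a group directly. Compound 1 also carries two methoxy groups and at 190 nM is the nearest guide, so this assay is expected to show a large step to a lower number. The estimated change is a 28-fold lower number from compound 2 to compound 4 (1.44 log units; beyond the scatter) in that direction. For compound 4 the estimated value is 800 nM within an expected range of 200 nM to 5000 nM as a working figure.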

Compound 4, half-maximal inhibitory concentration: 4300 nM
Compound 4: the middle estimate sits 5.4-fold (0.73 log units) below what was measured, and the stated range covers the measured number.
By their numbers in this assay, from the lowest: compound 1; then compound 4; then compound 2. At a limit, above all of these: compound 3.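

In this assay, a second methoxy at this place, meta to a methoxy group, gives a 5.1-fold lower number from compound 2 to compound 4 (0.71 log units; beyond the scatter) and so lowers the number, which the fluoro step could not show. The change on the saturated chain carbon bound to an amide-type nitrogen in a ring gives a 23-fold higher number from compound 1 to compound 4 (1.35 log units; beyond the scatter) and is printed as large, against modest for the methoxy step, so the second methoxy alone does not bring compound 4 to the level of compound 1. Nothing shown gives a cause for either step.

From the compounds shown here alone, whether a hydroxyl or an amine at this place would serve as the second methoxy does remains open.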